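A few compounds are considered here, and "the series" means these few. Any claim that something is new, unique, unknown or untested is made for them only; others in the source may bear on it.

Measured compounds in an ADME assay on Huh-7 cells (Homo sapiens) for cytotoxicity; a lower number here means that less compound is tolerated, a higher number that more compound is tolerated:

Compound 1 `CN(C)c1ccc(C(=O)NC(=S)N2CCc3c(OCCCCCOc4ccc(Cl)cc4)cccc32)cc1`. In this assay compound 1 gives > 50000 nM, which is a limit of the assay and not a number.
Compound 2 `O=C(CCc1ccccc1)NC(=S)N1CCc2c(OCCCCCOc3ccc(Cl)cc3)cccc21`. In this assay compound 2 gives > 50000 nM, again a limit.
Compound 3 `O=C(NC(=S)N1CCc2c(OCCCCCOc3ccc(Cl)cc3)cccc21)C1CCCC1`. In this assay compound 3 gives > 50000 nM, also a limit.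

Compound 3 thus stands at the limit, as do the other two; all values shown sit at the limit of > 50000 nM in this assay, at which 3 of the 3 values shown sit. None of the three steps among these compounds can be read: a step that the two limits leave unreadable from compound 1 to compound 2, a step that the two limits leave unreadable from compound 1 to compound 3 and a step that the two limits leave unreadable from compound 2 to compound 3 all lie between two limits.

Compound 4 `O=C(NC(=S)N1CCc2c(OCCCCCOc3ccc(Cl)cc3)cccc21)c1cccnc1` differs from compound 3 as follows: pyridin-3-yl in place of cyclopentyl on a carbonyl carbon. The steps that bear on this change are the ones into compound 3, from compound 1 and from compound 2, both unreadable, so the shown data give no readable size or direction for any step in this assay. What they do show is that three different groups on the carbonyl carbon all leave the value at the limit. On that basis no step beyond the scatter is expected, and compound 4 is expected to come out at the limit once more, meaning a step that the limit leaves unreadable from compound 3 to compound 4. The estimate for compound 4 in this assay is 70000 nM, with a range from 30000 nM to 150000 nM.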

Compound 4, half-maximal cytotoxic concentration: 11100 nM
For compound 4 the middle estimate is 6.3-fold (0.80 log units) above the measured one; the whole stated range lies above it.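

In this assay the group on the carbonyl carbon does register once pyridin-3-yl enters: in place of cyclopentyl it gives an at least 4.5-fold lower number from compound 3 to compound 4 (0.65 log units; beyond the scatter), in place of phenethyl an at least 4.5-fold lower number from compound 2 to compound 4 (0.65 log units; beyond the scatter), and in place of 4-(dimethylamino)phenyl an at least 4.5-fold lower number from compound 1 to compound 4 (0.65 log units; beyond the scatter). Each of these sizes is a minimum, and the steps among compounds 1, 2 and 3 cannot be read. An aromatic ring on the carbonyl carbon does not by itself go with the lower number, as compound 1 with its 4-(dimethylamino)phenyl shows, and the three compounds without a ring hetero atom at this place share one ceiling: the limit of > 50000 nM in this assay, at which 3 of the 4 values shown sit.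

The compounds shown cannot separate the ring nitrogen from the aromatic ring as such, since unsubstituted phenyl on the same carbonyl carbon would be needed for that comparison. As far as these compounds go, it also stays open whether the placing of that nitrogen matters, as pyridin-2-yl and pyridin-4-yl would show, and whether a second ring nitrogen, as in pyrimidin-5-yl, would move the number further.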